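Trading the acetyl for a methyl on the pendant phenyl

The source may report more compounds than this note shows. Statements on the series, on what has been measured and on what is new or still open speak of the compounds shown alone.

Compound 1 `COc1cc(-c2ccnc3cc(-c4ccc(C(C)=O)cc4)nn23)cc(OC)c1OC` gives 5230 nM in a functional assay on MCF7 cells (Homo sapiens) for inhibition, read by CCK-8 assay, with a stated time of 48 h (on this read-out lower numbers stand for stronger inhibition and higher numbers for weaker inhibition), the highest of the two numbers reported there; the nearer number belongs to compound 3 `COc1cc(-c2ccnc3cc(-c4cn(C(=O)OC(C)(C)C)c5ccccc45)nn23)cc(OC)c1OC`, which gives 268 nM. Compound 2 `CCOC(=O)c1ccc(-c2cc3nccc(-c4cc(OC)c(OC)c(OC)c4)n3n2)cc1` reaches only the limit > 10000 nM, a limit of the assay (the limit of > 10000 nM in this assay, at which 1 of the 3 values shown sits). Going by the values given here, the one measured step, an at least 1.9-fold higher number from compound 1 to compound 2 (0.28 log units; that floor lies within the scatter), concerns the carbonyl and does not reach the change to compound 4 `COc1cc(-c2ccnc3cc(-c4cccc(C)c4)nn23)cc(OC)c1OC`, in which (3-methylphenyl in place of 4-acetylphenyl on an aromatic carbon). Among the compounds with values here, no measured step bears directly on that change, so the expectation is loose: compound 4 is estimated at 3000 nM, with a range from 600 nM to 15000 nM, which is expected to mean a step of a 1.7-fold lower number from compound 1 to compound 4 (0.24 log units; within the scatter) within the scatter or only modestly beyond it.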

Compound 4, half-maximal inhibitory concentration: 1080 nM
Beside the measured number, compound 4's estimate is 2.8-fold (0.44 log units) above it; low and high end bracket the measured number.
By their numbers in this assay, from the lowest: compound 3; then compound 4; then compound 1. At a limit, above all of these: compound 2.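

Setting 3-methylphenyl in place of 4-acetylphenyl gives a 4.8-fold lower number from compound 1 to compound 4 (0.69 log units; beyond the scatter) in this assay, so at this position a phenyl ring without a carbonyl retains activity and reads better than the acetyl-bearing ring. The change replaces the group and also alters its place on the phenyl ring, and the step cannot be divided between the two. Nothing measured among the data shown explains the step.

Which of the two alterations carries the step stays open. So does the reading of an amine or a carboxylic acid on the phenyl ring, or of a longer chain in place of the methyl.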